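Near-equal growth inhibition across the aryl amide series

The source may hold more compounds than are shown below. What is called first, only, known or untested is meant among the compounds shown, and "the series" means these compounds.

Values in a functional assay on T47D cells (Homo sapiens) for inhibition, read by CCK-8 assay, with a stated time of 72 h, tested at 10 uM (a lower number here means less inhibition of growth, a higher number more inhibition of growth at the concentration tested), are as follows.
Compound 1 `Cc1cccc(NC(=O)C2(C(=O)Nc3ccc(Nc4ncc5cc(C(=O)N(C)C)n(C6CCCC6)c5n4)cc3)CC2)c1` gives 95.3%
Compound 2 `CN(C)C(=O)c1cc2cnc(Nc3ccc(NC(=O)C4(C(=O)Nc5cccc(Cl)c5)CC4)cc3)nc2n1C1CCCC1` gives 92.6%
Compound 3 `CN(C)C(=O)c1cc2cnc(Nc3ccc(NC(=O)C4(C(=O)Nc5cccc(Br)c5)CC4)cc3)nc2n1C1CCCC1` gives 94.6%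

Compound 3 lies within the scatter of both other compounds, and a number 0.7 percentage points lower from compound 1 to compound 3 (within the scatter) and a number 2 percentage points higher from compound 2 to compound 3 (within the scatter) are the steps that reach it. Compound 4 `CN(C)C(=O)c1cc2cnc(Nc3ccc(NC(=O)C4(C(=O)Nc5ccc(C(F)(F)F)cc5)CC4)cc3)nc2n1C1CCCC1` carries the change 4-(trifluoromethyl)phenyl in place of 3-bromophenyl on an amide-type nitrogen in the form of 4-(trifluoromethyl)phenyl in place of 3-bromophenyl on an amide-type nitrogen. The nearest evidence comes from swaps on an aromatic carbon: a number 2.7 percentage points lower from compound 1 to compound 2 (within the scatter) for chloro in place of methyl, with a number 0.7 percentage points lower from compound 1 to compound 3 (within the scatter) for bromo in place of methyl and a number 2 percentage points higher from compound 2 to compound 3 (within the scatter) for bromo in place of chloro. All of these stay within the scatter. None of them tests trifluoromethyl or 4-(trifluoromethyl)phenyl, so the support is indirect and the range is kept wide on the lower side. No change beyond the scatter is expected in this assay and the estimated step is a number 3.6 percentage points lower from compound 3 to compound 4 (within the scatter) as a small downward lean. The estimate for compound 4 is 91% with an expected range of 78% to 98% for this measurement.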

Compound 4, percent growth inhibition at one concentration: 94.9%
The estimate for compound 4 lay 3.9 percentage points below the measured number; the range from low to high includes it.
By their numbers in this assay, from the lowest: compounds 2, 3, 4 and 1 (each within the scatter of the next).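

The earlier compounds shown here varied only the substituent on an aromatic carbon, whereas compound 4 replaces the whole aryl group on the amide-type nitrogen. In this assay, the steps to 4-(trifluoromethyl)phenyl all stay within the scatter (a number 0.3 percentage points higher from compound 3 to compound 4 (within the scatter); a number 2.3 percentage points higher from compound 2 to compound 4 (within the scatter); a number 0.4 percentage points lower from compound 1 to compound 4 (within the scatter)), so this position accepts a change of both substituent and printed ring position, and the entering group's 10 heavy atoms against the 7 of 3-bromophenyl, without a readable change in growth inhibition. No measurement available here explains this result.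

The name of the substituent and its ring position change together in compound 4, so a 3-(trifluoromethyl)phenyl or 4-bromophenyl group would be needed to separate them. Going by these compounds, whether the position also accepts a group without the phenyl ring, such as a carboxylic acid or an amine, remains open.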